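Three Weak Analogues and an Aminophenyl Replacement

The compounds below may be only part of what the source reports. "The series", "measured", "known", "first", "only" and "open" are said of these compounds alone.

Compound 1, `COc1ccccc1Nc1nc(-c2cccc(F)c2)nc2ccc(F)cc12`, in a functional assay on HL-60 cells (Homo sapiens) for cytotoxicity, read by MTT assay, with a stated time of 48 h (on this read-out lower numbers stand for stronger inhibition and higher numbers for weaker inhibition), gives > 50000 nM, a limit of the assay.
Compound 2, `Fc1cccc(Nc2nc(-c3cccc(F)c3)nc3ccc(F)cc23)c1`, in this assay gives 43100 nM.
Compound 3, `Fc1cccc(-c2nc(Nc3ccc(Br)cc3)c3cc(F)ccc3n2)c1`, in this assay gives > 50000 nM, again a limit of the assay.

All three compounds share one core and differ only in the aryl group on the nitrogen attached to that core. Compound 3 stands at the ceiling of the measurement, and two of the three values shown sit there (the limit of > 50000 nM in this assay, at which 2 of the 3 values shown sit). The step of an at least 1.1-fold higher number from compound 2 to compound 3 (0.06 log units; that floor lies within the scatter) stays within the scatter, and the step that the two limits leave unreadable from compound 1 to compound 3 cannot be read at all, so none of these changes has moved the number in a way that can be trusted.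

Compound 4, `Nc1cccc(Nc2nc(-c3cccc(F)c3)nc3ccc(F)cc23)c1`, differs from compound 3 by 3-aminophenyl in place of 4-bromophenyl on a nitrogen on an aromatic ring. Every measured step here is either within the scatter or unreadable, so no direction is expected for an at least 1.1-fold lower number from compound 3 to compound 4 (0.04 log units; that floor lies within the scatter) beyond the scatter. Compound 4 is therefore expected to give about 45000 nM, between 15000 nM and 50000 nM.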

Compound 4, half-maximal inhibitory concentration: > 50000 nM
Compound 4 was reported as a limit; the forecaster's own chance of this, stated with the estimate: 55%; at least 1.1-fold (0.04 log units) between middle value and limit.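

In this assay compound 4 gives > 50000 nM, which is a limit of the assay. Amino in place of fluoro on an aromatic carbon, the one change that links compound 4 to the only compound with a true number, gives an at least 1.1-fold higher number from compound 2 to compound 4 (0.06 log units; that floor lies within the scatter), so putting an amino group on this aryl ring has not moved the result in a way that can be trusted. The steps to compound 4 from compound 1 and from compound 3 cannot be read, and the ceiling now holds most of the series: the limit of > 50000 nM in this assay, at which 3 of the 4 values shown sit.

As far as these compounds go, what stays open is whether any group on this nitrogen can bring the number clearly down. A carboxylic acid on the aryl ring, or a longer chain in its place, would test that.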